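From Methoxycarbonyl to Ethoxycarbonyl: Compound 3 to Compound 4

The source may report more compounds than this note shows. Statements on the series, on what has been measured and on what is new or still open speak of the compounds shown alone.

Three analogues sharing one core have been measured in an assay on cell membranes for displacement of a labelled ligand from proteinase-activated receptor 1 (Homo sapiens), read by scintillation counting, with a stated time of 60 min; on this read-out lower numbers stand for stronger inhibition and higher numbers for weaker inhibition. Compound 1 `Fc1cccc(-c2ccc(/C=C/[C@H]3C(OCc4ccccc4)C[C@@H]4CCCC[C@@H]43)nc2)c1` gives 280 nM, compound 2 `CS(=O)(=O)OC1C[C@@H]2CCCC[C@@H]2[C@H]1/C=C/c1ccc(-c2cccc(F)c2)cn1` gives 6.4 nM, and compound 3 `COC(=O)NC1C[C@@H]2CCCC[C@@H]2[C@H]1/C=C/c1ccc(-c2cccc(F)c2)cn1` gives 980 nM. Compound 3 thus stands highest of the three numbers: there was a 3.5-fold higher number from compound 1 to compound 3 (0.54 log units; beyond the scatter), and a 150-fold higher number from compound 2 to compound 3 (2.19 log units; beyond the scatter). Compound 4 `CCOC(=O)NC1C[C@@H]2CCCC[C@@H]2[C@H]1/C=C/c1ccc(-c2cccc(F)c2)cn1` differs from compound 3 by methyl in place of hydrogen on a saturated chain carbon bound to an oxygen next to a carbonyl group. For the measured compounds named here, no measured step bears directly on this change; each earlier step exchanged the whole group on the saturated ring carbon and lay beyond the scatter, whereas here only a single carbon is added, methyl becoming ethyl. The expectation for compound 4 is therefore a small step, a 1.1-fold lower number from compound 3 to compound 4 (0.04 log units; within the scatter), not beyond the scatter. Compound 4 is estimated at 900 nM, within a range of 300 nM to 2700 nM.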

Compound 4, half-maximal inhibitory concentration: 2000 nM
For compound 4 the middle estimate is 2.2-fold (0.35 log units) below the measured one; measured number inside the range.
By their numbers in this assay, from the lowest: compound 2; then compound 1; then compound 3; then compound 4.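

In this assay, the step from methyl to ethyl gives a 2.0-fold higher number from compound 3 to compound 4 (0.31 log units; beyond the scatter) and so shows that adding this single carbon to the methoxycarbonyl group already moves the number beyond the scatter, towards weaker inhibition. The (ethoxycarbonyl)amino group also stands further from the other groups on the saturated ring carbon, with a 310-fold higher number from compound 2 to compound 4 (2.49 log units; beyond the scatter) against (methylsulfonyl)oxy and a 7.1-fold higher number from compound 1 to compound 4 (0.85 log units; beyond the scatter) against benzyloxy. No evidence is available to explain these steps. Still open, going by these compounds, is whether a longer chain in place of ethyl continues this trend, and how (methylsulfonyl)amino or a free amine on the saturated ring carbon would compare.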